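The compounds below may be only part of what the source reports. "The series", "measured", "known", "first", "only" and "open" are said of these compounds alone.

Measured so far in a functional assay on the whole organism (strain Sprague-Dawley) for inhibition, with Rattus norvegicus as the target, with a stated time of 0.5 h, at a dose of 5 mg/kg by the oral route; a lower number here means less inhibition, a higher number more inhibition at the dose given (going by the name of the read-out):
- compound 1 `CCCSc1nc(N[C@@H]2C[C@H]2c2ccc(F)c(F)c2)c2nnn([C@@H]3C[C@H](OC(C)=O)[C@@H](O)[C@H]3O)c2n1`: compound 1 gives "not determined" (no result reported)
- compound 2 `CCCSc1nc(N[C@@H]2C[C@H]2c2ccc(F)c(F)c2)c2nnn([C@@H]3C[C@H](OC(=O)CCC)[C@@H](O)[C@H]3O)c2n1`: compound 2 gives 28.5%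
- compound 3 `CCCSc1nc(N[C@@H]2C[C@H]2c2ccc(F)c(F)c2)c2nnn([C@@H]3C[C@H](OCCOC(=O)CCC)[C@@H](O)[C@H]3O)c2n1`: compound 3 gives "not active" (no number reported)

Compound 3 stands without a single number in this assay: its result is reported only as a qualitative outcome, and compound 1 is a further entry without a number. For the measured compounds named here, the only number in the set is that of compound 2, which gives 28.5%; no step between compound 2 and compound 3 is computed, so the pair shows only a number on one side and none on the other.

Compound 4 `CCCSc1nc(N[C@@H]2C[C@H]2c2ccc(F)c(F)c2)c2nnn([C@@H]3C[C@H](OCCOC(=O)C(C)(C)C)[C@@H](O)[C@H]3O)c2n1` is the next entry. Compound 4 differs from compound 3 in one place: tert-butyl in place of propyl on a carbonyl carbon. The ester on the two-carbon linker is kept; only the group on its carbonyl carbon is exchanged.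

Going by the values given here, no measured step tells the size or direction of such an exchange. Given that compound 3 gives "not active" (no number reported), the expected outcome for compound 4 is no change beyond the usual scatter, and a fair chance that compound 4 is likewise reported without a number. Compound 4 is estimated at 10%, within a range from 0% to 30%.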

Compound 4, a percentage reported as inhibition, in the whole organism at one dose (the size of the read-out at that dose, not a potency): 46.1%
The estimate for compound 4 lay 36.1 percentage points below the measured number, outside the stated range (above it).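

In this assay the group on the carbonyl carbon of the ester on the two-carbon linker decides whether a number is reported at all: with propyl, compound 3 gives "not active" (no number reported) and with tert-butyl, compound 4 gives 46.1% at the same dose. The linker therefore does not rule out a reading at this oxygen, and the 2-(((tert-butyl)carbonyl)oxy)ethyl group in place of propylcarbonyl gives a number 17.6 percentage points higher from compound 2 to compound 4 (beyond the scatter) in this single-dose read-out, which is a size of effect and not a potency. Nothing measured here accounts for the difference between propyl and tert-butyl on this carbonyl carbon.

The compounds shown leave open whether the result with tert-butyl extends to other groups on that carbonyl carbon, such as cyclohexyl or a longer chain, or to an amine or a carboxylic acid at the end of the linker. They also leave open how tert-butyl behaves on the ester without the linker, and the shorter ester adds nothing, since compound 1 gives "not determined" (no result reported) in this assay here.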